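Thioether amine side chain on the shared core

The source may report more compounds than this note shows. Statements on the series, on what has been measured and on what is new or still open speak of the compounds shown alone.

In a functional assay on HT cells (Homo sapiens) for antiproliferative activity, read by fluorescence, with a stated time of 72 h (a lower number here means a stronger inhibitor of growth, a higher number a weaker inhibitor of growth), two compounds of the series have been measured:
compound 1 `CC(C)c1n[nH]c2c(NCc3ccc(-c4ccccn4)cc3)nc(SCC(N)CN)nc12`: 480 nM
compound 2 `CC(C)c1n[nH]c2c(NCc3ccc(-c4ccccn4)cc3)nc(SCCCN(C)C)nc12`: 105 nM

Compound 2 gives the lowest number of the two; compound 1 is the nearest, separated by a 4.6-fold lower number from compound 1 to compound 2 (0.66 log units; beyond the scatter). Compound 3 `CNCCSc1nc(NCc2ccc(-c3ccccn3)cc2)c2[nH]nc(C(C)C)c2n1` is not yet measured. It differs from compound 2 by methylamino in place of (dimethylamino)methyl on a saturated chain carbon, two bonds along the chain from a sulfur. Among the measured compounds shown here, the only step that bears on it is a 4.6-fold lower number from compound 1 to compound 2 (0.66 log units; beyond the scatter), in which 2-(dimethylamino)ethyl replaced 1,2-diaminoethyl; compound 3 moves part of the way back toward compound 1, so a modest rise in number is expected, a 1.9-fold higher number from compound 2 to compound 3 (0.28 log units; within the scatter). For compound 3 in this assay the estimate is 200 nM, range 80 nM to 500 nM.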

Compound 3, concentration for 50% growth inhibition: 56 nM
Estimate against measurement, compound 3: 3.6-fold (0.55 log units) above; the whole stated range lies above it.
By their numbers in this assay, from the lowest: compounds 3 and 2 (each within the scatter of the next); then compound 1.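

In this assay, trimming the side chain gives a 1.9-fold lower number from compound 2 to compound 3 (0.27 log units; within the scatter), so the 2-(methylamino)ethyl and 3-(dimethylamino)propyl chains are not separated at this position. The 1,2-diaminoethyl chain now stands apart from both, with an 8.6-fold lower number from compound 1 to compound 3 (0.93 log units; beyond the scatter) adding to the earlier step out of compound 1. No evidence on hand accounts for these numbers.

Chain length and the number of methyl groups on the nitrogen change together here, so neither can be read alone. A 2-(dimethylamino)ethyl, 3-(methylamino)propyl or plain 2-aminoethyl chain on the sulfur would separate them.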